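A few compounds are considered here, and "the series" means these few. Any claim that something is new, unique, unknown or untested is made for them only; others in the source may bear on it.

Working notes on the series. Among the measured compounds shown here, compound 1 `CCn1ncc2c(F)cc(-c3ccc(C(CC)(CC)c4nnc(C)[nH]4)c(=O)[nH]3)cc21` is the first member with a reading. In an ADME assay on microsomes from liver (Homo sapiens) for metabolic stability (on this read-out higher numbers stand for a longer-lived compound and lower numbers for a shorter-lived compound), compound 1 gives > 3 h, which is a limit of the assay and not a number. Compound 2 `CCC(CC)(c1nnc[nH]1)c1ccc(-c2ccc3cccc(F)c3c2)[nH]c1=O` is the second member. In this assay, for the measured compounds named here, compound 2 gives 1.19 h, the only reading in the set that is a number. Compound 3 `CC(C)C(Cc1noc(=O)[nH]1)c1ccc(-c2ccc3cccc(F)c3c2)[nH]c1=O` is the third member. In this assay compound 3 gives > 3 h, again a limit of the assay rather than a number. Compound 3 therefore sits at the limit of > 3 h in this assay, at which 2 of the 3 values shown sit, and nothing places it above or below compound 1. Going by the values given here, no pair of measured compounds differs in a single place, so no measured step is available as a precedent. The next member is compound 4 `CC(C)C(/C=C1\CCNC1=O)c1ccc(-c2ccc3cccc(F)c3c2)[nH]c1=O`, which differs from compound 3 by a group of 7 heavy atoms (5 carbon, 1 nitrogen, 1 oxygen; one five-membered non-aromatic ring with 1 hetero atom) in place of a group of 7 heavy atoms (3 carbon, 2 nitrogen, 2 oxygen; one five-membered aromatic ring with 3 hetero atoms), on a saturated chain carbon bound to an aromatic carbon and a saturated chain carbon. Without a measured step the size of this change in this assay is open; the expectation is a step from compound 3 of an at least 1.3-fold lower number from compound 3 to compound 4 (0.13 log units; that floor lies within the scatter), that is, a somewhat shorter half-life, though it may well stay within the scatter of the limit. For compound 4 the estimated half-life in this assay is 2.2 h, with a range from 0.9 h to 3.5 h.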

Compound 4, half-life: 0.713 h
The estimate for compound 4 lay 3.1-fold (0.49 log units) above the measured number, and the stated range ends above it.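

At the saturated chain carbon bound to an aromatic carbon and a saturated chain carbon, the group in place clearly matters in this assay: replacing the five-membered aromatic ring with 3 hetero atoms by the five-membered non-aromatic ring with 1 hetero atom gives an at least 4.2-fold lower number from compound 3 to compound 4 (0.62 log units; beyond the scatter). Among the compounds shown here, this is the first step that can be read, and it shows that a change at this carbon can move the half-life beyond the scatter even though both groups hold 7 heavy atoms. The size of the step remains a floor, because compound 3 stands at a limit of the assay and not at a number: the limit of > 3 h in this assay, at which 2 of the 4 values shown sit.

The compounds shown do not separate the parts of this exchange, as the ring type, the number of hetero atoms and the double bond outside aromatic rings all change together. As far as these compounds go, it also remains open how other groups on this carbon, such as a carboxylic acid, an amine or a simple open-chain amide, would read, and whether the step would carry over to the core of compound 1.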